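The source may hold more compounds than are shown below. What is called first, only, known or untested is meant among the compounds shown, and "the series" means these compounds.

Working notes on the series.

Compound 1 `CC(=O)Nc1ccc(S(=O)(=O)Nc2cccc(-c3nc(-c4ccc(NC(=O)c5cccnc5)cc4)no3)c2)cc1` carries the sulfonamide-linked core; in a functional assay on MDA-MB-231 cells (Homo sapiens) for antiproliferative activity, read by MTT assay, with a stated time of 72 h (on this read-out higher numbers stand for weaker inhibition and lower numbers for stronger inhibition), compound 1 gives 5200 nM. Compound 2 `CC(=O)Nc1ccc(S(=O)(=O)Nc2cccc(-c3nc(-c4ccc(NC(=O)c5cccnc5)c(Cl)c4)no3)c2)cc1` differs from it by chloro in place of hydrogen on an aromatic carbon, the change sitting ortho to a ((pyridin-3-yl)carbonyl)amino group and meta to a large group. In this assay compound 2 gives 4500 nM, so the change made a 1.2-fold lower number from compound 1 to compound 2 (0.06 log units; within the scatter).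

Compound 3 `CC(=O)Nc1ccc(NC(=O)Nc2cccc(-c3nc(-c4ccc(NC(=O)c5cccnc5)cc4Cl)no3)c2)cc1` belongs to the urea-linked core. For compound 3 this assay returns only a limit, > 10000 nM, that being (the limit of > 10000 nM in this assay, at which 1 of the 3 values shown sits). How the core of compound 3 differs from the core of compound 1 is not broken down here.

Compound 4 `CC(=O)Nc1ccc(NC(=O)Nc2cccc(-c3nc(-c4ccc(NC(=O)c5cccnc5)cc4Cl)no3)c2)cc1Cl`, not yet measured, differs from compound 3 by chloro in place of hydrogen on an aromatic carbon. This is the same kind of change as that from compound 1 to compound 2, but the surroundings differ: here the chloro enters ortho to an acetamido group (4 heavy atoms) and meta to a large group, whereas in the earlier case it entered ortho to a ((pyridin-3-yl)carbonyl)amino group (9 heavy atoms). Only one measured instance of this change exists among the compounds shown, so the expectation rests on it alone.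

Because a 1.2-fold lower number from compound 1 to compound 2 (0.06 log units; within the scatter) is within the scatter, the expected step is a step that the limit leaves unreadable from compound 3 to compound 4. Compound 4 is accordingly expected to give 12000 nM in this assay, with a likely span from 5000 nM to 30000 nM, and it is expected that the assay may again report only a limit for compound 4.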

Compound 4, half-maximal inhibitory concentration: > 10000 nM
Compound 4: only a limit was reported (the forecaster's own chance of this, stated with the estimate: 65%); the middle value does not contradict the limit.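

In this assay compound 4 returns only a limit, > 10000 nM. Compound 3 also stands at a limit, so no size can be read for the chloro change from compound 3 to compound 4: the limit of > 10000 nM in this assay, at which 2 of the 4 values shown sit.

The compounds shown leave open whether chloro in place of hydrogen on an aromatic carbon shifts the number at all on the urea-linked core.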